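The source may hold more compounds than are shown below. What is called first, only, known or untested is meant among the compounds shown, and "the series" means these compounds.

Values so far in a functional assay on HeLa cells (Homo sapiens) for inhibition, read by MTT assay, with a stated time of 48 h; on this read-out lower numbers stand for stronger inhibition and higher numbers for weaker inhibition
- compound 1 `CCOC(=O)C1=C(NN=C(C#N)C#N)Nc2[nH]nc(C)c2C1c1ccc(N(C)C)cc1` gives 15200 nM
- compound 2 `CCOC(=O)C1=C(N/C=N/c2ccc([N+](=O)[O-])cc2)Nc2[nH]nc(C)c2C1c1ccc(N(C)C)cc1` gives 57800 nM

Compound 2 gives the higher of the two numbers (57800 nM), with compound 1 lower by more than the scatter. Next in the series is compound 3 `CCOC(=O)C1=C(N/N=C(/C(C)=O)C(=O)OCC)Nc2[nH]nc(C)c2C1c1ccc(N(C)C)cc1`, and the change to it is a group of 10 heavy atoms (6 carbon, 1 nitrogen, 3 oxygen; no ring) in place of a group of 11 heavy atoms (7 carbon, 2 nitrogen, 2 oxygen; one six-membered aromatic ring of carbon only), on an amine nitrogen on the same amine nitrogen. The group that leaves carries one six-membered aromatic ring of carbon only, and the group that enters has no ring.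

Among the measured compounds shown here, one measured step bears on this: a 3.8-fold higher number from compound 1 to compound 2 (0.58 log units; beyond the scatter), a modest move that came with that ring-bearing group replacing a group with no ring. A partial return is therefore expected, with a lower number in this assay, although a single step gives thin support. The expected step is a 2.2-fold lower number from compound 2 to compound 3 (0.35 log units; beyond the scatter) (an estimate). Compound 3 is estimated at 26000 nM (expected range 11000 nM to 60000 nM).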

Compound 3, half-maximal inhibitory concentration: > 100000 nM
Compound 3 ended at the assay's limit; the forecaster's own chance of this, stated with the estimate: 5%; middle value at least 3.8-fold (0.58 log units) away from the limit.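

For compound 3, the reading in this assay is a limit of the assay and not a number: the limit of > 100000 nM in this assay, at which 1 of the 3 values shown sits. Taking the aromatic ring off this amine nitrogen gives an at least 1.7-fold higher number from compound 2 to compound 3 (0.23 log units; that floor lies within the scatter), so there is no sign of a lower number, although the true size of this step stays unknown. Two groups with no ring also part clearly, with an at least 6.5-fold higher number from compound 1 to compound 3 (0.81 log units; beyond the scatter), so across compound 1, compound 2 and compound 3 the absence of a ring does not by itself set the level in this assay.

The position of compound 3 on the scale remains unresolved, as does which part of its entering group goes with the weaker reading. Also open, from the compounds shown here alone, is how a small group on this amine nitrogen, such as methyl or acetyl, or a plain phenyl ring would read in this assay.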